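A few compounds are considered here, and "the series" means these few. Any claim that something is new, unique, unknown or untested is made for them only; others in the source may bear on it.

In a functional assay on A549 cells (Homo sapiens) for antiproliferative activity, read by MTT assay, with a stated time of 72 h (a lower number here means a stronger inhibitor, a higher number a weaker inhibitor), three compounds built on a shared core have been measured. Compound 1 `COc1ccc(/C=N/NC(=O)Nc2ccc(Oc3ccnc4[nH]ccc34)c(F)c2)cc1` gives 3980 nM, compound 2 `COc1ccc(/C=N/NC(=O)Nc2ccc(Oc3ccnc4[nH]ccc34)c(F)c2)c(OC)c1OC` gives 1450 nM and compound 3 `O=C(N/N=C/c1ccc(F)cc1)Nc1ccc(Oc2ccnc3[nH]ccc23)cc1` gives 1430 nM. Compound 2 and compound 3 lie within the scatter of each other, while the number of compound 1 lies higher than that of compound 2, beyond the scatter.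

Compound 4 `COc1ccc(/C=N/NC(=O)Nc2ccc(Oc3ccnc4[nH]ccc34)cc2)c(OC)c1OC` has not yet been measured. It differs from compound 2 at a single place: hydrogen in place of fluoro on an aromatic carbon. Going by the values given here, no measured pair isolates this change, so the expectation rests on indirect evidence. Compound 3, which also has hydrogen rather than fluoro on that ring but differs elsewhere, gives 1430 nM. No step beyond the scatter is expected in this assay, and no direction is favoured. The expected change is a 1.1-fold lower number from compound 2 to compound 4 (0.05 log units; within the scatter). The estimate for compound 4 is 1300 nM, with an expected range from 450 nM to 3800 nM.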

Compound 4, half-maximal inhibitory concentration: 3340 nM
Estimate against measurement, compound 4: 2.6-fold (0.41 log units) below; the measured number falls inside the stated range.
By their numbers in this assay, from the lowest: compounds 3 and 2 (each within the scatter of the next); then compounds 4 and 1 (each within the scatter of the next).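

In this assay, hydrogen in place of fluoro on an aromatic carbon, ortho to a large group and meta to a large group, gives a 2.3-fold higher number from compound 2 to compound 4 (0.36 log units; beyond the scatter). Going by these compounds alone, this is the first pair to isolate the position, and it shows that the fluoro counts here: the step is modest but lies beyond the scatter, with the fluoro-bearing compound 2 as the stronger inhibitor of the two. Nothing shown explains the step.

Going by these compounds, the step rests on this single pair, so whether fluoro has the same effect with other groups at the far end of the molecule remains open. Also open, on these data alone, is how a chlorine atom, a methyl group or a methoxy group on this same carbon would compare with fluoro.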